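Adding one methoxy to compound 1: what to expect

The compounds below may be only part of what the source reports. "The series", "measured", "known", "first", "only" and "open" are said of these compounds alone.

Compound 1 `COc1c(OC)c(OC(=O)C(C)(C)C)c2ccccc2c1OC(=O)C(C)(C)C` is the starting point here. In a physicochemical assay for lipophilicity (a lower number here means a more polar compound, a higher number a more lipophilic compound), compound 1 gives 5.69, and its close relative compound 2 `COc1c(OC)c(OC(=O)C(C)(C)C)c2c(OC)cccc2c1OC(=O)C(C)(C)C` gives 5.6, so the two lie within the usual scatter of each other. Compound 3 `COc1ccc2c(OC(=O)C(C)(C)C)c(OC)c(OC)c(OC(=O)C(C)(C)C)c2c1` has not been measured yet. It differs from compound 1 by a single change: methoxy in place of hydrogen on an aromatic carbon. The new methoxy sits in place of hydrogen on an aromatic carbon, meta to a fused ring and para to a fused ring.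

Within the data shown here, only one measured step is of the same kind: a number 0.09 log units lower from compound 1 to compound 2 (within the scatter). That swap falls on a different carbon, so it is a guide and not a direct match. Going by it, no shift beyond the scatter is expected in this assay. The expected step is a number 0.07 log units lower from compound 1 to compound 3 (within the scatter). Compound 3 is estimated at 5.62, with an expected range from 5.25 to 6.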

Compound 3, partition coefficient: 5.4
For compound 3 the middle estimate is 0.22 log units above the measured one, within the range that was stated.
By their numbers in this assay, from the lowest: compounds 3, 2 and 1 (each within the scatter of the next).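

In this assay, methoxy in place of hydrogen on this carbon, meta to a fused ring and para to a fused ring, gives a number 0.29 log units lower from compound 1 to compound 3 (within the scatter) and so does not separate from compound 1. The earlier step showed this for one carbon only; with compound 3, the same swap at a second carbon of the shared core has also produced no change that can be told apart from the scatter. Nothing available explains the size of this step, or says what the methoxy does at this carbon.

As far as these compounds go, whether an amine, a carboxylic acid or a longer chain on this same carbon would move the number beyond the scatter remains open. So does whether methoxy on other carbons of the core would behave the same way.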